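This account rests on a few compounds, and the source may have more. Where it says the series, first, only, none or still open, it means among the compounds named here.

Compound 1 `CCc1ccc(SCc2ccc(C(=O)Nc3ccccc3N)cc2)cc1`: 19.6%
Compound 2 `Nc1ccccc1NC(=O)c1ccc(CSc2cccc(F)c2)cc1`: 37.7%
Compound 3 `Cc1ccc(SCc2ccc(/C=C/C(=O)Nc3ccccc3N)cc2)cc1`: 22.9%

In a functional assay on A-375 cells (Homo sapiens) for inhibition, read by CCK-8 assay, with a stated time of 72 h, tested at 2 uM (on this read-out higher numbers stand for more inhibition of growth at the one concentration tested and lower numbers for less inhibition of growth), compound 2 gives 37.7%, the highest of these three numbers, and its gaps to compound 1 and to compound 3 both lie beyond the usual scatter. The next compound to be tested is compound 4 `Nc1ccccc1NC(=O)c1ccc(CSc2ccc(Br)cc2)cc1`. Its change from compound 2 is 4-bromophenyl in place of 3-fluorophenyl on a sulfur.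

Among the measured compounds shown here, only one measured step bears directly on this change. It is a number 18.1 percentage points higher from compound 1 to compound 2 (beyond the scatter), a modest step beyond the scatter, made by putting 3-fluorophenyl in place of 4-ethylphenyl on a sulfur. Compound 4 gives up the same 3-fluorophenyl and again carries a group named as a 4-substituted phenyl, so part of that gain may well be lost. For the measured compounds named here, compound 3, at 22.9%, has no single-place step to the others and offers only weak support. Going by the values given here, no compound with bromine has been measured, so this reasoning rests on a single comparison and remains uncertain.

The expected change is a number 10.7 percentage points lower from compound 2 to compound 4 (beyond the scatter), a modest drop. The estimated value for compound 4 is 27%, with an expected range of 13% to 42%.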

Compound 4, percent growth inhibition at one concentration: 4.35%
The estimate for compound 4 lay 22.7 percentage points above the measured number; measured number outside the range, below it.
By their numbers in this assay, from the lowest: compound 4; then compounds 1 and 3 (each within the scatter of the next); then compound 2.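

In this assay, among the compounds shown here, the group on the sulfur proves to matter more than the one earlier step could show: 4-bromophenyl in place of 3-fluorophenyl gives a number 33.4 percentage points lower from compound 2 to compound 4 (beyond the scatter) and this is a large step. The second new step shows that carrying a group at the 4-position of the phenyl ring does not by itself fix the outcome, since bromo in place of ethyl on an aromatic carbon gives a number 15.3 percentage points lower from compound 1 to compound 4 (beyond the scatter) as a modest step. Two rings named alike as 4-substituted phenyl therefore differ clearly here, and the substituent itself counts as well as where it sits.

Going from 3-fluorophenyl to 4-bromophenyl changes both the halogen and its numbered place on the ring in one move, so the two changes cannot be told apart, and 4-fluorophenyl or 3-bromophenyl would separate them, while 4-aminophenyl would test a quite different kind of substituent. Nothing available here explains why these rings give such different numbers.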